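A few compounds are considered here, and "the series" means these few. Any claim that something is new, unique, unknown or untested is made for them only; others in the source may bear on it.

Measured compounds:
- compound 1, `COc1ccc(C2=NN(c3ccccc3)C(c3ccc(C)cc3)C2S(=O)(=O)CC2=NCCO2)cc1`: 62.5%
- compound 2, `COc1ccc(-c2nn(-c3ccccc3)c(-c3ccc(C)cc3)c2S(=O)(=O)CC2=NCCS2)cc1`: "not active" (no number reported)

In a functional assay, tested at 50 ug/mL (a higher number here means a stronger effect of the compound at the concentration tested, a lower number a weaker effect), compound 1 gives 62.5%. Within the data shown here, compound 2 stands apart: in this assay compound 2 is reported only as "not active" (no number reported), so no single number describes where it lies, and its distance from compound 1 cannot be put into a figure; the two values show only that compound 1 produced a clear effect and compound 2 did not.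

Compound 3, `COc1ccc(-c2nn(-c3ccccc3)c(-c3ccc(C)cc3)c2S(=O)(=O)CC2=NCCO2)cc1`, differs from compound 2 in one place: a group of 5 heavy atoms (3 carbon, 1 nitrogen, 1 oxygen; one five-membered non-aromatic ring with 2 hetero atoms) in place of a group of 5 heavy atoms (3 carbon, 1 nitrogen, 1 sulfur; one five-membered non-aromatic ring with 2 hetero atoms), on a saturated chain carbon bound to a sulfonyl sulfur. Among the measured compounds shown here, no measured pair in this set carries that same change, so its effect on this assay is not known from the data. Compound 3 shares the core of compound 2 rather than that of compound 1, and compound 2 gave no activity; a modest rise above inactivity seems the most that should be expected, but a step of any clear size in either direction cannot be claimed. Compound 3 is therefore estimated at 20% in this assay, within a range of 0% to 50%.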

Compound 3, a percentage reported as activity, at one concentration (the size of the read-out at that concentration, not a potency): 67.6%
Estimate against measurement, compound 3: 47.6 percentage points below, outside the stated range (above it).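

In this assay, among these compounds, compound 2 carries no number, so no step from compound 2 to compound 3 can be read. Nothing in the data shown accounts for the result. The compounds shown leave open how large the effect of the oxygen-containing ring in place of the sulfur-containing ring is, on a saturated chain carbon bound to a sulfonyl sulfur.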